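Working notes: ether for thioether on the triazole arm

The source may hold more compounds than are shown below. What is called first, only, known or untested is meant among the compounds shown, and "the series" means these compounds.

Measured compounds:
compound 1, `O=c1cc(-n2cc(CSc3ccccc3)nn2)c2cc(Br)ccc2o1`, in a functional assay on MCF7 cells (Homo sapiens) for antiproliferative activity, read by MTT assay, with a stated time of 48 h (a higher number here means a weaker inhibitor, a lower number a stronger inhibitor), compound 1 gives 36800 nM
compound 2, `O=c1cc(-n2cc(COc3ccccc3)nn2)c2cc(Br)ccc2o1`, in this assay compound 2 gives 1720 nM
compound 3, `O=c1cc(-n2cc(COc3ccnc4ccc(Br)cc34)nn2)c2cc(Br)ccc2o1`, in this assay compound 3 gives 41600 nM

Compound 1 stands second highest of the three numbers. Compound 3 sits nearest, within the scatter of compound 1, so the two cannot be ordered. Within the data shown here, compound 2 sits furthest, reached by a 21-fold lower number from compound 1 to compound 2 (1.33 log units; beyond the scatter), the only single-point step in the set.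

Compound 4, `O=c1cc(-n2cc(COc3ccccc3Br)nn2)c2cc(Br)ccc2o1`, is not yet measured. It differs from compound 1 by 2-bromophenoxy in place of phenylsulfanyl on a saturated chain carbon bound to an aromatic carbon. The swap of the sulfur-linked ring for an oxygen-linked ring is the same swap as a 21-fold lower number from compound 1 to compound 2 (1.33 log units; beyond the scatter); the added bromine on the entering ring has no single-point comparison of its own. Compound 3 carries a bromine on a larger oxygen-linked ring system and gives a number close to compound 1, but it differs from compound 2 in more than one place, so it neither confirms nor denies the effect of the bromine alone.

For compound 4 a large drop in this assay is therefore expected, on the order of a 12-fold lower number from compound 1 to compound 4 (1.09 log units; beyond the scatter), with some allowance for the unexplored bromine. The estimate for compound 4 is 3000 nM, with a range of 900 nM to 12000 nM.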

Compound 4, half-maximal inhibitory concentration: 28900 nM
Beside the measured number, compound 4's estimate is 9.6-fold (0.98 log units) below it; measured number above the stated range.
By their numbers in this assay, from the lowest: compound 2; then compounds 4, 1 and 3 (each within the scatter of the next).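

In this assay, bromo in place of hydrogen on an aromatic carbon gives a 17-fold higher number from compound 2 to compound 4 (1.23 log units; beyond the scatter), so the low number of compound 2 does not survive this single addition to the phenoxy ring. With 2-bromophenoxy in place of phenylsulfanyl, the step is a 1.3-fold lower number from compound 1 to compound 4 (0.10 log units; within the scatter), which leaves the two compounds unordered and shows that an oxygen-linked ring does not by itself bring the large drop: it appears with phenoxy in compound 2 but not with 2-bromophenoxy in compound 4. The data shown offer no measurement that explains the loss.

Fluoro, methoxy or an amine in place of the bromo would show whether the step belongs to bromo alone or to any group at that carbon. Going by these compounds, whether a phenylsulfanyl ring carrying the same bromo would respond in the same way also stays open.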